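A few compounds are considered here, and "the series" means these few. Any claim that something is new, unique, unknown or untested is made for them only; others in the source may bear on it.

In a functional assay on KB cells (Homo sapiens) for cytotoxicity (on this read-out lower numbers stand for an effect already at smaller amounts and higher numbers for an effect only at larger amounts of compound), compound 1 `COC1=C(C)C(=O)/C(=C(O)/C=C/c2ccc(OC)cc2)C(=O)C1(C)C` gives 3.6 ug/mL, compound 2 `COC1=C(C)C(=O)/C(=C(O)/C=C/c2ccccc2OC)C(=O)C1(C)C` gives 3.3 ug/mL, and compound 3 `COC1=C(C)C(=O)/C(=C(O)/C=C/c2ccc(C)cc2)C(=O)C1(C)C` gives 3.9 ug/mL. Compound 3 therefore stands level with the other two compounds. Its steps, a 1.1-fold higher number from compound 1 to compound 3 (0.03 log units; within the scatter) and a 1.2-fold higher number from compound 2 to compound 3 (0.07 log units; within the scatter), lie within the scatter, as does a 1.1-fold lower number from compound 1 to compound 2 (0.04 log units; within the scatter).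

Compound 4 `COC1=C(C)C(=O)/C(=C(O)/C=C/c2ccco2)C(=O)C1(C)C` has furan-2-yl in place of 4-methylphenyl on a double-bonded chain carbon bound to a double-bonded chain carbon. Among the measured compounds shown here, none of the measured steps exchanges the six-membered aromatic ring of carbon only for a five-membered aromatic ring, so the data offer no direct precedent. The closest guide is the step of a 1.2-fold higher number from compound 2 to compound 3 (0.07 log units; within the scatter), which also removes one aryl group in favour of another and stays within the scatter. On that limited basis, no step beyond the scatter is expected in this assay, and no direction can be favoured. The estimated result is a 1.0-fold lower number from compound 3 to compound 4 (0.01 log units; within the scatter). For compound 4 the expected value is 3.8 ug/mL, with an estimated range from 1.8 ug/mL to 7.5 ug/mL.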

Compound 4, concentration for half-maximal effect: 9.9 ug/mL
Compound 4: the middle estimate sits 2.6-fold (0.42 log units) below what was measured; the measured number lies above the stated range.
By their numbers in this assay, from the lowest: compounds 2, 1 and 3 (each within the scatter of the next); then compound 4.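

In this assay the earlier aryl groups at this place, on a double-bonded chain carbon bound to a double-bonded chain carbon, stood level with one another, so exchanging one six-membered aromatic ring for another had shown no effect. Furan-2-yl is the first group here to move the number beyond the scatter, with a 2.5-fold higher number from compound 3 to compound 4 (0.40 log units; beyond the scatter) and a 3.0-fold higher number from compound 2 to compound 4 (0.48 log units; beyond the scatter) and a 2.8-fold higher number from compound 1 to compound 4 (0.44 log units; beyond the scatter) all modest and all in the same direction, so this position does respond to the change to a five-membered aromatic ring with one hetero atom. Nothing given here accounts for this shift.

The compounds shown leave open whether the higher number goes with the smaller ring or with its oxygen, which thiophen-2-yl at this place would help to separate. Also open, on these data alone, is whether an amine or a carboxylic acid on the six-membered aromatic ring would move the number beyond the scatter, as methyl and methoxy did not.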